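Series notes: amine substituent on the piperidine, compound 3

A few compounds are considered here, and "the series" means these few. Any claim that something is new, unique, unknown or untested is made for them only; others in the source may bear on it.

Measured so far:
Compound 1, `COc1cc(N)c(Cl)cc1NC(=O)C1CCN(CC2CCC2)CC1`, in a functional assay on the whole organism for antagonist activity, with Mus musculus as the target (a lower number here means that less compound is needed, a higher number that more compound is needed for the effect), gives > 10 mg/kg, a limit of the assay and not a number.
Compound 2, `COc1ccc(CN2CCC(C(=O)Nc3cc(Cl)c(N)cc3OC)CC2)cc1`, in this assay gives 0.9 mg/kg.

Compound 2 holds the only number shown in this assay; compound 1 sits at the limit of > 10 mg/kg in this assay, at which 1 of the 2 values shown sits. For the measured compounds named here, the one measured step, an at least 11-fold lower number from compound 1 to compound 2 (1.04 log units; beyond the scatter), rests on 4-methoxyphenyl in place of cyclobutyl on a saturated chain carbon bound to an amine nitrogen in a ring.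

Compound 3, `COc1cc(N)c(Cl)cc1NC(=O)C1CCN(Cc2ccccc2F)CC1`, is not yet measured. It differs from compound 2 by 2-fluorophenyl in place of 4-methoxyphenyl on a saturated chain carbon bound to an amine nitrogen in a ring. Both groups are aromatic rings at the same place, so the measured step from compound 1 to compound 2 does not bear directly on this change: nothing shown separates one aryl group from another. Going by the values given here, with no step to lean on, the expectation is a step from compound 2 to compound 3 of about a 1.7-fold higher number from compound 2 to compound 3 (0.22 log units; within the scatter), not beyond the scatter in either direction. Compound 3 is therefore estimated at 1.5 mg/kg in this assay, within the range 0.5 mg/kg to 5 mg/kg.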

Compound 3, dose for half-maximal effect: > 4 mg/kg
Compound 3: a limit, no number (the forecaster's own chance of this, stated with the estimate: 15%); middle value at least 2.6-fold (0.42 log units) away from the limit.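

In this assay, the identity of the aromatic ring on this saturated chain carbon matters: 2-fluorophenyl in place of 4-methoxyphenyl gives an at least 4.4-fold higher number from compound 2 to compound 3 (0.64 log units; beyond the scatter), so an aromatic ring at this place is not enough on its own to give a number like that of compound 2. Compound 3 gives a limit of the assay and not a number: the limit of > 4 mg/kg in this assay, at which 1 of the 3 values shown sits. Compound 1 and compound 3 both stand at limits, and the step between them cannot be read, so the compounds shown do not order 2-fluorophenyl against cyclobutyl.

On these data alone, the change from 4-methoxyphenyl to 2-fluorophenyl swaps the substituent and its place on the ring together, so it remains open whether the higher number follows the loss of methoxy, the arrival of fluorine or the change of place; unsubstituted phenyl, 4-fluorophenyl and 2-methoxyphenyl on the same carbon would separate these readings. Also open, as far as these compounds go, is whether 4-methoxyphenyl keeps its number in this assay with a longer chain, such as 2-(4-methoxyphenyl)ethyl, on the amine nitrogen.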